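The source may report more compounds than this note shows. Statements on the series, on what has been measured and on what is new or still open speak of the compounds shown alone.

In a functional assay on MDA-MB-231 cells for antagonist activity at C-X-C chemokine receptor type 4 (Homo sapiens), tested at 10 nM (a lower number here means a weaker effect, a higher number a stronger effect of the compound at the concentration tested), compound 1 `c1ccc(NCc2ccc(CNc3ccccc3)cc2)cc1` gives 54%. Compound 2 `Fc1cccc(NCc2ccc(CNc3cccc(F)n3)cc2)n1` gives 55% in this assay, and compound 3 `Fc1ccc(NCc2ccc(CNc3ccc(F)cn3)cc2)nc1` gives 45%. Among these three numbers compound 1 stands second highest; its nearest is compound 2 and its furthest is compound 3, both within the usual scatter of the measurement.

Compound 4 `c1ccc(NCc2ccc(CNc3ncccn3)cc2)cc1` has not yet been measured in this assay. It differs from compound 1 in one place: pyrimidin-2-yl in place of phenyl on an amine nitrogen. Among the compounds with values here, no measured pair of compounds shows this change on its own. As the three measured numbers lie within the scatter of each other, the step of a number 6 percentage points lower from compound 1 to compound 4 (within the scatter) is expected to stay within the scatter, in no clear direction. Compound 4 is therefore expected to give about 48%, between 30% and 65%.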

Compound 4, a percentage reported as inhibition, at one concentration (the size of the read-out at that concentration, not a potency): 55%
Compound 4: middle estimate off by 7 percentage points, on the low side; low and high end bracket the measured number.
By their numbers in this assay, from the lowest: compounds 3, 1, 2 and 4 (each within the scatter of the next).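

Pyrimidin-2-yl in place of phenyl on one amine nitrogen gives a number 1 percentage points higher from compound 1 to compound 4 (within the scatter) in this assay, the first single change that can be read at this position. An aromatic ring with 2 hetero atoms and 2 hydrogen-bond acceptors thus takes the place of a carbon-only ring with no change beyond the scatter at this one concentration. Nothing shown here accounts for this result.

The compounds shown leave open whether a saturated ring such as cyclohexyl, or a carboxylic acid on the ring, would hold this level at the same amine nitrogen.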